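This account rests on a few compounds, and the source may have more. Where it says the series, first, only, none or still open, it means among the compounds named here.

Measured so far:
Compound 1 `Cc1cc(-c2c(F)cc3c(=O)ccn(C4CC4)c3c2F)cc(C)n1` — 15000 nM
Compound 2 `Cc1cc(-c2c(F)cc3c(=O)c(Cc4ccc(Cl)cc4)cn(C4CC4)c3c2F)cc(C)n1` — 20000 nM

Both were tested in a functional assay on P388 cells (Mus musculus) for cytotoxicity; a lower number here means a stronger inhibitor, a higher number a weaker inhibitor. Compound 2 holds the higher of the two numbers, but the gap to compound 1 is within the scatter, so the two cannot be told apart. Compound 3 `Cc1cc(-c2c(F)cc3c(=O)c(Cc4c[nH]cn4)cn(C4CC4)c3c2F)cc(C)n1` differs from compound 2 by 1H-imidazol-4-yl in place of 4-chlorophenyl on a saturated chain carbon bound to an aromatic carbon. For the measured compounds named here, only one measured step bears on this: placing 4-chlorobenzyl in place of hydrogen on an aromatic carbon gave a 1.3-fold higher number from compound 1 to compound 2 (0.12 log units; within the scatter), within the scatter. Nothing measured shows how exchanging that group for 1H-imidazol-4-yl acts, so no step beyond the scatter is expected in this assay. Compound 3 is estimated at 20000 nM (range 7000 nM to 50000 nM), an expected step of no change at the digits printed from compound 2 to compound 3 (within the scatter).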

Compound 3, half-maximal inhibitory concentration: 390 nM
The estimate for compound 3 lay 51-fold (1.71 log units) above the measured number; measured number outside the range, below it.
By their numbers in this assay, from the lowest: compound 3; then compounds 1 and 2 (each within the scatter of the next).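

In this assay, this position proves sensitive to what is placed on it: adding (1H-imidazol-4-yl)methyl in place of hydrogen gives a 38-fold lower number from compound 1 to compound 3 (1.59 log units; beyond the scatter), whereas 4-chlorobenzyl gave no step beyond the scatter. Exchanging 4-chlorophenyl for 1H-imidazol-4-yl gives a 51-fold lower number from compound 2 to compound 3 (1.71 log units; beyond the scatter), so among these compounds the ring on the saturated chain carbon sets the outcome. No evidence is available to explain this difference. Still open, as far as these compounds go, is whether an amine on that chain carbon, or a longer chain carrying 1H-imidazol-4-yl, would give a similarly low number.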